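Swapping Trifluoromethyl for Nitro on a Benzyl Ether

The source may report more compounds than this note shows. Statements on the series, on what has been measured and on what is new or still open speak of the compounds shown alone.

Three compounds share one core and were tested in a functional assay on A549 cells (Homo sapiens) for antiproliferative activity, read by MTT assay, with a stated time of 72 h; a higher number here means a weaker inhibitor, a lower number a stronger inhibitor. Compound 1 `O=[N+]([O-])c1ccc(COc2ccc(Nc3ncnc4cc5c(cc34)OCCOCCO5)cc2)cc1` gives 8620 nM, compound 2 `FC(F)(F)c1ccc(COc2cccc(Nc3ncnc4cc5c(cc34)OCCOCCOCCOCCO5)c2)cc1` gives 8520 nM, and compound 3 `FC(F)(F)c1ccc(COc2ccc(Nc3ncnc4cc5c(cc34)OCCOCCOCCO5)cc2)cc1` gives 30700 nM. Among the three, compound 2 has the lowest number, though compound 1 sits within the scatter of it; only compound 3 lies beyond the scatter, with a higher number. Compound 4 `O=[N+]([O-])c1ccc(COc2cccc(Nc3ncnc4cc5c(cc34)OCCOCCOCCOCCO5)c2)cc1` has not yet been measured in this assay. It differs from compound 2 in one place: nitro in place of trifluoromethyl on an aromatic carbon. Going by the values given here, no measured pair shows this change on its own, so the expected step is a 1.1-fold higher number from compound 2 to compound 4 (0.02 log units; within the scatter), small and in no direction beyond the scatter. Compound 4 is expected to give about 9000 nM in this assay, within a range from 3000 nM to 27000 nM.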

Compound 4, half-maximal inhibitory concentration: 19800 nM
Compound 4: middle estimate off by 2.2-fold (0.34 log units), on the low side, within the range that was stated.
By their numbers in this assay, from the lowest: compounds 2 and 1 (each within the scatter of the next); then compounds 4 and 3 (each within the scatter of the next).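

The step of a 2.3-fold higher number from compound 2 to compound 4 (0.37 log units; beyond the scatter) in this assay shows that going from 4-(trifluoromethyl)benzyl to 4-nitrobenzyl is not neutral at this position: the nitro compound has the higher number, though the step is modest. Compounds 1 and 3 could not show this, since they differ in more than one place. Nothing measured here explains the difference between these two groups.

As far as these compounds go, whether a nitrile or a carboxylic acid in this place would give a lower number than trifluoromethyl remains open. So does whether the same swap gives a similar step on another core.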